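Adding a sulfonyl group to compound 2

The compounds below may be only part of what the source reports. "The series", "measured", "known", "first", "only" and "open" are said of these compounds alone.

Compound 1 `COc1ccc(/C=C2\CN(C)C/C(=C\c3cccnc3)C2=O)c(OC)c1OC` gives 13700 nM as its value
Compound 2 `O=C1/C(=C/c2cccnc2)CNC/C1=C\c1ccccc1F` gives > 20000 nM as its value

In a functional assay on SMMC-7721 cells (Homo sapiens) for cytotoxicity, read by MTT assay, with a stated time of 24 h (on this read-out lower numbers stand for stronger inhibition and higher numbers for weaker inhibition), compound 1 gives 13700 nM as a true number. Compound 2 gives > 20000 nM as its reading, which is a limit of the assay and not a number. Compound 3 `O=C1/C(=C/c2cccnc2)CN(S(=O)(=O)c2ccc(Cl)cc2)C/C1=C\c1ccccc1F` has (4-chlorophenyl)sulfonyl in place of hydrogen on an amine nitrogen in a ring. Among the measured compounds shown here, no measured step shows what this change does, so in this assay a moderate move toward stronger inhibition is only an expectation. The estimated size of this move is (an at least 3.3-fold lower number from compound 2 to compound 3 (0.52 log units; beyond the scatter)). Compound 3 is expected at 6000 nM (range 1500 nM to 20000 nM).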

Compound 3, half-maximal inhibitory concentration: 16100 nM
Estimate against measurement, compound 3: 2.7-fold (0.43 log units) below; measured number inside the range.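

In this assay compound 3, with (4-chlorophenyl)sulfonyl in place of hydrogen on the amine nitrogen in the ring, gives 16100 nM, a true number. Compound 2 gives > 20000 nM, which is a limit of the assay. The change gives an at least 1.2-fold lower number from compound 2 to compound 3 (0.09 log units; that floor lies within the scatter), and its real size stays unknown because only a floor can be read: the limit of > 20000 nM in this assay, at which 1 of the 3 values shown sits.

Still open, from the compounds shown here alone, is whether the sulfonyl link or the chlorinated ring matters more. An acetyl group or an unsubstituted benzenesulfonyl group on this nitrogen would help to separate the two.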